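Aryl swap on the piperazine: methoxy to methyl

The compounds below may be only part of what the source reports. "The series", "measured", "known", "first", "only" and "open" are said of these compounds alone.

For the measured compounds named here, compound 2 `COc1ccc(N2CCN(CCCNc3ncccc3C(=O)N(C)C)CC2)c(OC)c1` stands as the highest of the two numbers so far in a functional assay on aorta for antagonist activity at Alpha-1D adrenergic receptor (Rattus norvegicus); on this read-out higher numbers stand for weaker binding and lower numbers for tighter binding. Its nearest neighbour, compound 1 `CN(C)C(=O)c1cccnc1NCCCN1CCN(c2ccccc2C2CC2)CC1`, gives 63.1 nM, whereas compound 2 gives 1000 nM; the step of a 16-fold higher number from compound 1 to compound 2 (1.20 log units; beyond the scatter) is the only measured one in the set. Compound 3 `COc1cc(C)ccc1N1CCN(CCCNc2ncccc2C(=O)N(C)C)CC1` differs from compound 2 by methyl in place of methoxy on an aromatic carbon. Going by the values given here, the one measured step concerns the exchange of the whole aryl group on the ring amine nitrogen, not a single substituent on it, so no step in this assay bears directly on the change from methoxy to methyl. With nothing measured that points one way, the expectation for the step from compound 2 to compound 3 in this assay is a modest one, estimated as a 1.4-fold lower number from compound 2 to compound 3 (0.15 log units; within the scatter). Compound 3 is therefore estimated at 700 nM, with a range from 250 nM to 2000 nM.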

Compound 3, dissociation constant: 39.8 nM
Compound 3: middle estimate off by 18-fold (1.25 log units), on the high side; measured number outside the range, below it.
By their numbers in this assay, from the lowest: compounds 3 and 1 (each within the scatter of the next); then compound 2.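

In this assay, exchanging methoxy for methyl on the aromatic carbon para to a large group alone gives a 25-fold lower number from compound 2 to compound 3 (1.40 log units; beyond the scatter), so this single position carries a large share of the difference among these aryl groups. The methoxy group retained in compound 3 does not itself bring the high number seen for compound 2, and the step to 2-methoxy-4-methylphenyl reads as a 1.6-fold lower number from compound 1 to compound 3 (0.20 log units; within the scatter), leaving that aryl group and 2-cyclopropylphenyl within the scatter. Nothing at hand bears on why methoxy and methyl part so widely at this carbon.

Still open, from the compounds shown here alone, is how chlorine, a nitrile or an amine would read at this same carbon. The compounds shown also leave open whether this step holds with a longer chain linking the ring amine nitrogen to the shared core.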